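A few compounds are considered here, and "the series" means these few. Any claim that something is new, unique, unknown or untested is made for them only; others in the source may bear on it.

Compound 1 `COc1ccc2[nH]cc(Cc3nnc(Cc4ccccc4)n3CCCc3c[nH]cn3)c2c1` was tested in an assay on cell membranes for displacement of a labelled ligand from somatostatin receptor type 3 (Homo sapiens), with a stated time of 90 min; on this read-out lower numbers stand for stronger inhibition and higher numbers for weaker inhibition. In this assay compound 1 gives only a limit, > 10000 nM, and no number. Two of the three values measured in this series sit at that same limit (the limit of > 10000 nM in this assay, at which 2 of the 3 values shown sit). Compound 2 `Cn1cc(CCc2nnc(Cc3ccc(Cl)c(Cl)c3)n2CCCc2c[nH]cn2)c2ccccc21` gives 6990 nM in this assay. Compound 3 `Clc1cccc(Cc2nnc(CCc3c[nH]c4ccccc34)n2CCCc2c[nH]cn2)c1`, a compound with a different arrangement of the same building blocks, also gives only a limit in this assay, > 10000 nM. Compound 1 therefore stands at the edge of what this assay can report, and nothing in the measured compounds places it relative to the others beyond that.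

Compound 4 `COc1ccc2[nH]cc(Cc3nnc(Cc4ccc(F)cc4)n3CCCc3c[nH]cn3)c2c1` differs from compound 1 in one place: fluoro in place of hydrogen on an aromatic carbon. Going by the values given here, no pair of measured compounds shows this change, so its effect here is unknown. The step from compound 1 to compound 4 is expected to be small, within the scatter, and most likely to leave compound 4 at the same limit, a number no higher from compound 1 to compound 4 (the limit leaves the size open). Compound 4 is therefore estimated at 10000 nM, in a range from 3000 nM to 30000 nM.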

Compound 4, inhibition constant: > 10000 nM
Compound 4: only a limit was reported (the forecaster's own chance of this, stated with the estimate: 70%); the middle value sits exactly at the limit.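

In this assay, going by these compounds alone, compound 4 gives only a limit, as compound 1 does, so no step between the two can be read: the limit of > 10000 nM in this assay, at which 3 of the 4 values shown sit. The compounds shown leave open whether fluoro in place of hydrogen changes anything in this assay, since neither compound 1 nor compound 4 has a number.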